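A few compounds are considered here, and "the series" means these few. Any claim that something is new, unique, unknown or untested is made for them only; others in the source may bear on it.

The compounds share one amide-linked core. Compound 1 `Cc1cc(NC(=O)Cn2nnc(-c3ccccc3)n2)n(C2CCOCC2)n1` gives 115% in an assay on HEK293 cells for activation of Kir3.1/Kir3.2 (Homo sapiens), read by thallium flux; on this read-out lower numbers stand for smaller maximal responses and higher numbers for larger maximal responses. Compound 2 `Cc1cc(NC(=O)Cn2nnc(-c3ccccc3)n2)n(C2CCC(C)(C)CC2)n1` is recorded in this assay only as a limit, > 19%, and the limit of > 19% in this assay, at which 1 of the 3 values shown sits, marks where that limit sits. Among the compounds with values here, the one measured step, a step that the limit leaves unreadable from compound 1 to compound 2, is thus left unreadable by that limit. Compound 3 `Cc1cc(NC(=O)Cn2nnc(-c3cccnc3)n2)n(C2CCCCC2)n1` gives 96% in this assay, which is the lowest of the two numbers shown; its nearest neighbour is compound 1, whose number lies higher by a gap beyond the scatter. The remaining entry, that of compound 2, is a limit and so gives no number to set beside it.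

Compound 4 `Cc1ccc(-c2nnn(CC(=O)Nc3cc(C)nn3C3CCCCC3)n2)cc1` has not yet been measured. Its change from compound 3 is 4-methylphenyl in place of pyridin-3-yl on an aromatic carbon. Within the data shown here, no measured step bears on a change at this place: the only measured step concerns the group on the aromatic nitrogen and has no readable size. With nothing to go on, no step beyond the scatter is expected, so the step to compound 4 is estimated as a number 1 percentage points lower from compound 3 to compound 4 (within the scatter), a shift that would stay within the usual scatter. Compound 4 is therefore expected to give about 95% in this assay, with a range from 60% to 125%.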

Compound 4, largest response reached (Emax), in percent of the reference or control that the assay uses: 86%
The estimate for compound 4 lay 9 percentage points above the measured number; measured number inside the range.
By their numbers in this assay, from the lowest: compounds 4 and 3 (each within the scatter of the next); then compound 1.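

Within the data shown here, the first readable step in this assay lies at this position, on the aromatic carbon of the five-membered aromatic ring with 4 nitrogen, where 4-methylphenyl in place of pyridin-3-yl gives a number 10 percentage points lower from compound 3 to compound 4 (within the scatter) and the two numbers thus stand within the scatter of each other. In this single pair, then, the ring nitrogen and the hydrogen-bond acceptor of pyridin-3-yl can be given up for a ring of carbon only with a methyl group on it, and the maximal response stays in the same range as that of compound 3. Nothing measured here speaks to why these two compounds lie so close together.

Compound 2 is recorded only as a limit, so the step leading to it cannot be read, and the effect of the group on the aromatic nitrogen remains unsettled. Also open, on these data alone, is whether an amine, a carboxylic acid or a longer chain in place of the methyl of 4-methylphenyl would keep the response in this range, and whether the exchange seen here would read the same with oxan-4-yl on the aromatic nitrogen.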